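Methyl Branching of the Ester Chain, Measured Once Already

The source may report more compounds than this note shows. Statements on the series, on what has been measured and on what is new or still open speak of the compounds shown alone.

Three compounds have been measured in an assay on membranes from CHO cells for displacement of a labelled ligand from adenosine receptor A1 (Homo sapiens), read by scintillation counting, with a stated time of 60 min, tested at 1 uM; a higher number here means more inhibition at the concentration tested (going by the name of the read-out), a lower number less inhibition:

compound 1, `CCCOC(=O)C1=C(C)NC(=S)NC1c1ccco1`, gives 1%
compound 2, `CC1=C(C(=O)OCC(C)C)C(c2ccco2)NC(=S)N1`, gives 7%
compound 3, `CCCOC(=O)C1=C(C)NC(=S)NC1c1ccsc1`, gives 5%

All three numbers are low and lie within the usual scatter of one another, so no order among them can be read from the data.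

Compound 1 and compound 2 differ by methyl in place of hydrogen on a saturated chain carbon bound to two saturated chain carbons. This change moved the read-out by a number 6 percentage points higher from compound 1 to compound 2 (within the scatter). Compound 1 and compound 3 differ in their cores by thiophen-3-yl in place of furan-2-yl on a saturated ring carbon, and that step came to a number 4 percentage points higher from compound 1 to compound 3 (within the scatter).

Compound 4, `CC1=C(C(=O)OCC(C)C)C(c2ccsc2)NC(=S)N1`, has not yet been measured. It stands to compound 3 as compound 2 stands to compound 1: the difference is methyl in place of hydrogen on a saturated chain carbon bound to two saturated chain carbons, and the surroundings of the change are described in the same words for both pairs, so it is the same change, made on the core of compound 3 rather than that of compound 1.

For the measured compounds named here, the one earlier instance of this change, a number 6 percentage points higher from compound 1 to compound 2 (within the scatter), was within the scatter, and compound 3 itself sits at 5%. Going by the values given here, on that basis the step from compound 3 to compound 4 is expected to be a number 5 percentage points higher from compound 3 to compound 4 (within the scatter), again within the scatter, because the only precedent is a number 6 percentage points higher from compound 1 to compound 2 (within the scatter). Compound 4 is therefore estimated to give 10% in this assay , with a plausible range from 0% to 22%.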

Compound 4, a percentage reported as inhibition, at one concentration (the size of the read-out at that concentration, not a potency): 8%
For compound 4 the middle estimate is 2 percentage points above the measured one, and the stated range covers the measured number.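

In this assay, the methyl change on the core of compound 3 came to a number 3 percentage points higher from compound 3 to compound 4 (within the scatter), and thiophen-3-yl in place of furan-2-yl, with the isobutoxy chain in place, came to a number 1 percentage points higher from compound 2 to compound 4 (within the scatter). Set beside its earlier instance, the methyl change shows no difference between the two cores that stands clear of the scatter: the same change on two cores in this assay, a number 6 percentage points higher (within the scatter) from compound 1 to compound 2 and a number 3 percentage points higher (within the scatter) from compound 3 to compound 4, 3 percentage points apart, within the scatter of two such steps. The ring change reads the same way, but since every one of these steps lies within the scatter, the series shows only that no dependence on the core appeared, not that either change has a real effect that carries from one core to another: the same change on two cores in this assay, a number 4 percentage points higher (within the scatter) from compound 1 to compound 3 and a number 1 percentage points higher (within the scatter) from compound 2 to compound 4, 3 percentage points apart, within the scatter of two such steps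

On these data alone, all four compounds give small numbers at one concentration, so it remains open whether the methyl change would carry in the same way on a compound whose read-out is large enough for a step to stand clear of the scatter. Also open, as far as these compounds go, is what a longer chain on the ester, a carboxylic acid in place of the ester, or a phenyl ring in place of furan-2-yl and thiophen-3-yl would give in this assay.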